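The compounds below may be only part of what the source reports. "The series", "measured", "known", "first", "only" and "open" are said of these compounds alone.

Of the compounds shown here, two of a shared core have been measured. Compound 1 `O=C(O)c1ccc([N+](=O)[O-])c(COc2ccc(/C=C3\SC(=S)N(c4ccccc4)C3=O)cc2)c1` is measured in an assay on isolated protein for inhibition of Apoptosis regulator Bcl-2 (Homo sapiens), read by fluorescence polarization (on this read-out lower numbers stand for stronger inhibition and higher numbers for weaker inhibition), where compound 1 gives 9000 nM. Compound 2 `Cc1cccc(N2C(=O)/C(=C/c3ccc(OCc4ccc(C(=O)O)cc4)cc3)SC2=S)c1` reaches only a limit of this assay, not a number: in this assay compound 2 gives > 10000 nM. That limit is the point where one of the two values shown sits (the limit of > 10000 nM in this assay, at which 1 of the 2 values shown sits), so compound 2 stands at the weak end of what has been seen here. Compound 3 `O=C(O)c1ccc(COc2ccc(/C=C3\SC(=S)N(c4ccc(I)cc4)C3=O)cc2)cc1` is not yet measured in this assay. It differs from compound 2 in one place: 4-iodophenyl in place of 3-methylphenyl on an amide-type nitrogen in a ring. Going by the values given here, no measured step of the same kind is available, so the expected step of an at least 1.2-fold lower number from compound 2 to compound 3 (0.09 log units; that floor lies within the scatter) is small, none beyond the usual scatter. Compound 3 is therefore estimated to give 8000 nM in this assay, with a range from 2000 nM to 30000 nM.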

Compound 3, inhibition constant: 4300 nM
Beside the measured number, compound 3's estimate is 1.9-fold (0.27 log units) above it; the range from low to high includes it.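

In this assay, 4-iodophenyl in place of 3-methylphenyl on the amide-type nitrogen in a ring gives an at least 2.3-fold lower number from compound 2 to compound 3 (0.36 log units; beyond the scatter). Going by these compounds alone, this is the first measured step at this position, and it shows that changing only the aromatic group on this nitrogen can shift the read-out beyond the usual scatter, even though both groups have the same count of heavy atoms. Compound 2 stands at a limit of the assay, not at a number, so this step gives only the smallest size the change could have: the limit of > 10000 nM in this assay, at which 1 of the 3 values shown sits.

The change swaps the methyl group for iodine and also alters where the substituent sits on the phenyl ring, and these two effects cannot be told apart here. A 4-methylphenyl or 3-iodophenyl group on the same nitrogen would separate them, while a 4-chlorophenyl group would test whether iodine itself is needed.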